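The source may report more compounds than this note shows. Statements on the series, on what has been measured and on what is new or still open speak of the compounds shown alone.

Measured compounds in a functional assay on Huh-7 cells (Homo sapiens) for cytotoxicity, read by CCK-8 assay, with a stated time of 72 h; a lower number here means a stronger inhibitor, a higher number a weaker inhibitor:

Compound 1, `C=CCn1c(=O)/c(=C\c2ccc(Cl)c(Cl)c2)[nH]c(=O)/c1=C\c1ccccc1`: "not active" (no number reported)
Compound 2, `C=CCn1c(=O)/c(=C\c2cc(F)ccc2C)[nH]c(=O)/c1=C\c1ccccc1OC`: 5600 nM
Compound 3, `COc1ccccc1/C=c1\c(=O)[nH]/c(=C/c2ccccc2Cl)c(=O)n1C`: 300 nM

Of the compounds shown here, three built on the shared core have been tested in this assay. For compound 1 no number was reported, only that it was not active. Of the two compounds with numbers, compound 2 stands highest: in this assay compound 2 gives 5600 nM, while compound 3 gives 300 nM, a gap between the two that lies beyond the usual scatter. Compound 2 and compound 3 differ in more than one place, so nothing can be said about which of those differences carries the gap.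

Compound 4, `C=CCn1c(=O)/c(=C\c2cc(Br)ccc2F)[nH]c(=O)/c1=C\c1ccccc1OC`, has not yet been measured in this assay. It differs from compound 2 in one place: 5-bromo-2-fluorophenyl in place of 5-fluoro-2-methylphenyl on a double-bonded chain carbon bound to an aromatic carbon. For the measured compounds named here, no pair of measured compounds differs in exactly this way, so the data give no direct guide to the size of the step. Going by the values given here, compound 1, with a dichlorophenyl group and a plain phenyl group, was not active, and that is the only other halogen-bearing example on this side of the core. The step is expected to be small, most likely within the scatter, with a slight lean toward a lower number. Compound 4 is estimated at 4000 nM, within 1500 nM to 12000 nM, an expected step of a 1.4-fold lower number from compound 2 to compound 4 (0.15 log units; within the scatter).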

Compound 4, half-maximal inhibitory concentration: "not active" (no number reported)
For compound 4 the study gives words and no number, so the estimate cannot be set against anything.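

In this assay, for the compounds shown here, compound 4 is reported in words alone, so no step from compound 2 to compound 4 can be read. Nothing shown gives a reason for this result. The compounds shown leave open how far 5-bromo-2-fluorophenyl in place of 5-fluoro-2-methylphenyl shifts the number in this assay.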